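A few compounds are considered here, and "the series" means these few. Any claim that something is new, unique, unknown or untested is made for them only; others in the source may bear on it.

Measured so far:
- compound 3 `CCCN(Cc1cccs1)C(=O)COc1ccc(C)cc1` — 40 nM
- compound 1 `Cc1ccc(OCC(=O)N(Cc2cccs2)c2ccn(C)n2)cc1` — 855 nM
- compound 2 `Cc1ccc(OCC(=O)N(Cc2cccs2)C2CCCCC2)cc1` — 40000 nM

In an assay on HEK293 cells for agonist activity at transient receptor potential cation channel subfamily M member 8 (Homo sapiens), read by fluorescence and calcium flux, with a stated time of 15 min (on this read-out higher numbers stand for an effect only at larger amounts of compound and lower numbers for an effect already at smaller amounts), compound 3 stands lowest of the three measured compounds, and both of its steps to the others lie beyond the scatter. The group on the amide-type nitrogen decides the read-out strongly: a 21-fold lower number from compound 1 to compound 3 (1.33 log units; beyond the scatter), a 1000-fold lower number from compound 2 to compound 3 (3.00 log units; beyond the scatter), and a 47-fold higher number from compound 1 to compound 2 (1.67 log units; beyond the scatter). Of the three groups tried there, the propyl of compound 3 gives the lowest number by a wide margin.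

Compound 4 `C=CCN(Cc1cccs1)C(=O)COc1ccc(C)cc1` keeps everything of compound 3 except for one change: vinyl in place of ethyl on a saturated chain carbon bound to an amide-type nitrogen. Within the data shown here, none of the measured steps covers this change directly; each of them exchanges the whole group on the amide-type nitrogen, whereas here the chain keeps its length and only one bond within it changes. The large steps seen so far therefore give the scale of what that position can do, but not the sign or size for this particular change. With the chain count unchanged, the expected step from compound 3 to compound 4 is a 1.4-fold higher number from compound 3 to compound 4 (0.14 log units; within the scatter), not beyond the scatter. For compound 4 in this assay the estimate is 55 nM, with a range from 15 nM to 200 nM.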

Compound 4, half-maximal effective concentration: 20 nM
Beside the measured number, compound 4's estimate is 2.8-fold (0.44 log units) above it; low and high end bracket the measured number.
By their numbers in this assay, from the lowest: compounds 4 and 3 (each within the scatter of the next); then compound 1; then compound 2.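

In this assay, among these compounds, this is the first change inside the chain on the amide-type nitrogen rather than an exchange of the whole group, and it gives a 2.0-fold lower number from compound 3 to compound 4 (0.30 log units; within the scatter); at this place, a saturated chain carbon bound to an amide-type nitrogen, vinyl in place of ethyl therefore brings no step that can be told from the scatter. The wide gaps to the two ring-bearing groups persist with allyl in the propyl position, with a 2000-fold lower number from compound 2 to compound 4 (3.30 log units; beyond the scatter) when allyl replaces cyclohexyl and a 43-fold lower number from compound 1 to compound 4 (1.63 log units; beyond the scatter) when allyl replaces 1-methyl-1H-pyrazol-3-yl, so among these compounds the large steps at this nitrogen come with exchanging the whole group, and none of the compounds shown goes against this. Nothing at hand gives a reason for either the small step or the large ones.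

Still open, from the compounds shown here alone, is how far the chain on this nitrogen can be varied, for instance with a longer chain such as butyl, a branched one such as isopropyl, or propargyl with its triple bond. Also open, going by these compounds, is whether a small ring such as cyclopropyl, or an amine or a carboxylic acid at the chain end, would stay near the propyl and allyl numbers or move toward those of the larger ring groups.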